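A few compounds are considered here, and "the series" means these few. Any claim that something is new, unique, unknown or untested is made for them only; others in the source may bear on it.

Measured compounds in an assay on THP-1 cells for displacement of a labelled ligand from C-C chemokine receptor type 1 (Homo sapiens); on this read-out higher numbers stand for weaker inhibition and lower numbers for stronger inhibition:

compound 1, `Cc1ccc(C(=O)N[C@@H](C(=O)N2CCC(c3ccc(Cl)cc3)CC2)C(C)C)cc1`, gives 25 nM
compound 2, `Cc1ccccc1C(=O)N[C@@H](C(=O)N1CCC(c2ccc(Cl)cc2)CC1)C(C)C`, gives 32 nM

For the measured compounds named here, compound 2 holds the higher of the two numbers so far, but the step of a 1.3-fold higher number from compound 1 to compound 2 (0.11 log units; within the scatter) lies within the scatter, so compound 1 and compound 2 cannot be told apart on this read-out.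

Compound 3, `CC(C)[C@@H](NC(=O)c1ccc(F)cc1)C(=O)N1CCC(c2ccc(Cl)cc2)CC1`, has not yet been measured. It differs from compound 2 in one place: 4-fluorophenyl in place of 2-methylphenyl on a carbonyl carbon. Going by the values given here, only one measured step exists, a 1.3-fold higher number from compound 1 to compound 2 (0.11 log units; within the scatter), and it concerns a different change, the exchange of 4-methylphenyl for 2-methylphenyl on the same carbonyl carbon; it left the number essentially where it was. Among the compounds with values here, no measured step covers a fluorine on that ring, so the data give no direction for compound 3. Given how little the one known change in this part of the molecule moved the number, no step beyond the scatter is expected in this assay.

Compound 3 is therefore expected at 30 nM, with a range of 12 nM to 80 nM. The estimated step is a 1.1-fold lower number from compound 2 to compound 3 (0.03 log units; within the scatter).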

Compound 3, half-maximal inhibitory concentration: 118 nM
Compound 3: middle estimate off by 3.9-fold (0.59 log units), on the low side, and the stated range ends below it.
By their numbers in this assay, from the lowest: compounds 1 and 2 (each within the scatter of the next); then compound 3.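

In this assay, the group on the carbonyl carbon proves able to move the number: the exchange of 2-methylphenyl for 4-fluorophenyl gives a 3.7-fold higher number from compound 2 to compound 3 (0.57 log units; beyond the scatter), a step beyond the scatter, which the earlier pair did not show. The comparison that changes only the substituent, fluoro in place of methyl on an aromatic carbon, gives a 4.7-fold higher number from compound 1 to compound 3 (0.67 log units; beyond the scatter), so among these three compounds the two methyl-bearing compounds remain within the scatter of each other while the fluoro compound stands apart with weaker inhibition. No measurement shown here accounts for this difference.

From the compounds shown here alone, whether the weaker inhibition belongs to fluoro itself or simply to the loss of methyl remains open, and a plain phenyl on the same carbonyl carbon would be the direct test of that. Going by these compounds, how a chloro, methoxy or ethyl group would compare at this place also remains open, so these three compounds define no trend across substituents.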